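Compound 3 to compound 4: substitution on sulfur

This account rests on a few compounds, and the source may have more. Where it says the series, first, only, none or still open, it means among the compounds named here.

- compound 1 `COc1ccc(-n2c(SCc3ccc(F)cc3)nnc2-c2cc(OC)c(OC)c(OC)c2)cc1` gives 50700 nM
- compound 2 `COc1ccc(-n2c(SCC(=O)Nc3ccc(Cl)cc3)nnc2-c2cc(OC)c(OC)c(OC)c2)cc1` gives 58000 nM
- compound 3 `COc1cc(-c2nnc(S)n2-c2ccc(N(C)C)cc2)cc(OC)c1OC` gives > 60000 nM

Going by the values given here, all three entries come from a functional assay on HT-29 cells (Homo sapiens) for inhibition, read by MTT assay, with a stated time of 48 h (a lower number here means a stronger inhibitor, a higher number a weaker inhibitor), and only two of them are numbers. Among the compounds with values here, compound 3 has only a limit and no number, with the limit of > 60000 nM in this assay, at which 1 of the 3 values shown sits, and no measured step leading from it.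

Compound 4 `COc1ccc(C(=O)CSc2nnc(-c3cc(OC)c(OC)c(OC)c3)n2-c2ccc(N(C)C)cc2)cc1`, not yet measured, carries ((4-methoxyphenyl)carbonyl)methyl in place of hydrogen on a sulfur, counted as ((4-methoxyphenyl)carbonyl)methyl in place of hydrogen on a sulfur and with the rest of compound 3 unchanged.

Within the data shown here, one measured step bears on this change, a 1.1-fold higher number from compound 1 to compound 2 (0.06 log units; within the scatter) and it stays within the scatter, so exchanging one group on the sulfur chain for another shows no effect in that pair. Compound 1 at 50700 nM and compound 2 at 58000 nM both carry a substituent on the sulfur and both return a number in this assay while also differing from compound 4 elsewhere on the core. Among the measured compounds shown here, no measured pair shows the hydrogen on the sulfur being replaced. A modest move towards a lower number is therefore expected, and a result at the limit remains possible.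

The expected size of the change is an at least 1.7-fold lower number from compound 3 to compound 4 (0.23 log units; that floor lies within the scatter) as estimated here. Compound 4 is estimated at 35000 nM with an expected range from 10000 nM to 60000 nM in this assay for now.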

Compound 4, half-maximal inhibitory concentration: 64000 nM
Compound 4: the middle estimate sits 1.8-fold (0.26 log units) below what was measured; measured number above the stated range.
By their numbers in this assay, from the lowest: compounds 1, 2 and 4 (each within the scatter of the next).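

No step from compound 3 to compound 4 can be read in this assay, because compound 3 carries only a limit: the limit of > 60000 nM in this assay, at which 1 of the 4 values shown sits.

Still open is how ((4-methoxyphenyl)carbonyl)methyl in place of hydrogen on a sulfur shifts the number in this assay, as compound 3 is the only compound shown with that hydrogen.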